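Compound 3 to compound 4: a series at limit

The source may hold more compounds than are shown below. What is called first, only, known or untested is meant among the compounds shown, and "the series" means these compounds.

Measured in an ADME assay on Raji cells (Homo sapiens) for cytotoxicity, read by luminescence, with a stated time of 72 h (a higher number here means that more compound is needed for the effect, a lower number that less compound is needed), each value a limit:
- compound 1 `CCOC(=O)c1c(-c2cccc(OC)c2)[nH]c2cc(OC)c(Cl)cc2c1=O`: > 21500 nM
- compound 2 `CCOC(=O)c1c(-c2cccc(Cl)c2)[nH]c2cc(OC)c(Cl)cc2c1=O`: > 21500 nM
- compound 3 `CCOC(=O)c1c(-c2cccc(Br)c2)[nH]c2cc(OC)c(Cl)cc2c1=O`: > 21500 nM

Compound 3 has only a limit, > 21500 nM, and no number. Going by the values given here, the series so far shows (the limit of > 21500 nM in this assay, at which 3 of the 3 values shown sit). Compound 4 `CCOC(=O)c1c(-c2cc(F)cc(OC)c2)[nH]c2cc(OC)c(Cl)cc2c1=O` carries 3-fluoro-5-methoxyphenyl in place of 3-bromophenyl on an aromatic carbon. The measured steps that bear on this are a step that the two limits leave unreadable from compound 1 to compound 3, a step that the two limits leave unreadable from compound 2 to compound 3 and a step that the two limits leave unreadable from compound 1 to compound 2. None of them has a readable size. With compound 3 at the limit > 21500 nM, no step beyond the scatter is expected in this assay, and another limit is the likeliest report. The expected step is a step that the limit leaves unreadable from compound 3 to compound 4. Compound 4 is estimated at 25000 nM, with an expected range of 10000 nM to 60000 nM.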

Compound 4, half-maximal effective concentration: > 21500 nM
Compound 4: only a limit was reported; the forecaster's own chance of this, stated with the estimate: 85%; the middle value lies beyond the limit too.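

In this assay compound 4 gives > 21500 nM, a limit, so its steps from compound 1, compound 2 and compound 3 cannot be read. The compounds shown leave open which change, if any, would give a measurable value: the limit of > 21500 nM in this assay, at which 4 of the 4 values shown sit.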